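Octylsulfanyl gives way to cyclohexylamino on the shared core

A few compounds are considered here, and "the series" means these few. Any claim that something is new, unique, unknown or untested is made for them only; others in the source may bear on it.

Compound 1 `Nc1nc(NC2CC2)c2ncn(/C=C3/CC3(CO)CO)c2n1`: > 20000 nM (a limit)
Compound 2 `CCCCCCCCSc1nc(N)nc2c1ncn2/C=C1/CC1(CO)CO`: 60000 nM

Within the data shown here, in an ADME assay on CCRF-HSB-2 cells (Homo sapiens) for cytotoxicity, with a stated time of 7 days (on this read-out lower numbers stand for higher toxicity in this test and higher numbers for lower toxicity in this test), compound 2 gives 60000 nM, the only actual number so far. Compound 1 is reported only as a limit, > 20000 nM. Compound 3 `Nc1nc(NC2CCCCC2)c2ncn(/C=C3/CC3(CO)CO)c2n1` differs from compound 2 by one change: cyclohexylamino in place of octylsulfanyl on an aromatic carbon. Among the measured compounds shown here, the only measured step bearing on it, a step that the limit leaves unreadable from compound 1 to compound 2, has no readable size, so no change beyond the usual scatter is expected in this assay. The expected step is a 1.2-fold lower number from compound 2 to compound 3 (0.08 log units; within the scatter). The estimate for compound 3 is 50000 nM, with an expected range of 20000 nM to 120000 nM.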

Compound 3, half-maximal cytotoxic concentration: > 20000 nM
Compound 3 was reported as a limit (the forecaster's own chance of this, stated with the estimate: 45%); the middle value lies beyond the limit too.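

No new step can be read from compound 2 to compound 3 or from compound 1 to compound 3 in this assay, because compound 3 is reported only as a limit: the limit of > 20000 nM in this assay, at which 2 of the 3 values shown sit.

The compounds shown leave open whether cyclohexylamino, cyclopropylamino and octylsulfanyl on the shared core differ at all in this read-out.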